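One added hydroxy on compound 1: what to expect

The compounds below may be only part of what the source reports. "The series", "measured", "known", "first", "only" and "open" are said of these compounds alone.

Values in a physicochemical assay, read by spectrophotometry, with a stated time of 30 min; on this read-out lower numbers stand for an effect already at smaller amounts and higher numbers for an effect only at larger amounts of compound:
Compound 1 `O=C1c2c(O)cc(O)cc2O[C@@H](c2ccccc2O)[C@@H]1O` gives > 100000 nM (a limit)
Compound 2 `O=C1c2c(O)cc(O)cc2O[C@@H](c2cccc(O)c2O)[C@@H]1O` gives 13500 nM (a number)
Compound 3 `O=C1c2c(O)cc(O)cc2O[C@H](c2ccccc2O)[C@H]1O` gives > 100000 nM (a limit)

In this assay compound 1 stands at > 100000 nM and that is a limit, not a number. Compound 3 likewise gives only a limit, > 100000 nM in the same assay.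

Compound 4 `O=C1c2c(O)cc(O)cc2O[C@@H](c2c(O)cccc2O)[C@@H]1O` has not yet been measured. It departs from compound 1 by hydroxy in place of hydrogen on an aromatic carbon with hydroxy in place of hydrogen on an aromatic carbon, ortho to a large group and meta to a hydroxy group.

One measured step is of this same kind: an at least 7.4-fold lower number from compound 1 to compound 2 (0.86 log units; beyond the scatter) and compound 2 reads 13500 nM as a true number. The other step, a step that the two limits leave unreadable from compound 1 to compound 3 reflects the fact that compounds 1 and 3 differ only in the configuration as drawn and has no bearing on an added hydroxy.

With a single precedent, a lower number is expected in this assay but its size is uncertain, and the reading may stay at the limit. The expected change is an at least 2.0-fold lower number from compound 1 to compound 4 (0.30 log units; that floor lies within the scatter) as an estimate. Compound 4 is estimated at 50000 nM (expected range 15000 nM to 100000 nM).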

Compound 4, half-maximal effective concentration: 100000 nM
Compound 4: the middle estimate sits 2.0-fold (0.30 log units) below what was measured, within the range that was stated.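

In this assay the added hydroxy at this place, ortho to a large group and meta to a hydroxy group, gives a number no higher from compound 1 to compound 4 (the limit leaves the size open); that size cannot be read, because the starting value is only a limit: the limit of > 100000 nM in this assay, at which 2 of the 4 values shown sit. Compound 4 gives 100000 nM as a number, and compound 2, which carries the same kind of added hydroxy at another place on the aromatic ring, gives 13500 nM. The kind of change alone therefore does not fix the reading, and the place of the hydroxy goes with a different value.

From the compounds shown here alone, whether a methoxy group or an amine at this place would read differently from the hydroxy stays open. So does whether the mirror image of compound 4 would read as compound 4 does.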